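This account rests on a few compounds, and the source may have more. Where it says the series, first, only, none or still open, it means among the compounds named here.

Measured so far in a physicochemical assay for solubility, at pH 7.4; on this read-out lower numbers stand for lower solubility and higher numbers for higher solubility:
compound 1 `Cc1c2c(n3c1CCN(C(=O)[C@H](C)N)CC[C@H](C)Nc1cc-3ccc1C(N)=O)CC(C)(C)CC2=O` — > 100 ug/mL
compound 2 `Cc1c2c(n3c1CCN(C(=O)CN)C[C@@H](C)[C@H](C)Nc1cc-3ccc1C(N)=O)CC(C)(C)CC2=O` — 46 ug/mL

Among the compounds with values here, only two compounds have been measured in this assay. Compound 1 gives > 100 ug/mL, which is a limit of the assay and not a number; it sits at the limit of > 100 ug/mL in this assay, at which 1 of the 2 values shown sits. Within the data shown here, compound 2 gives 46 ug/mL, the only plain number in the set, so there is no measured step between compounds to serve as a guide.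

Compound 3 `Cc1c2c(n3c1CCN(C(=O)C(C)(C)N)C[C@@H](C)[C@H](C)Nc1cc-3ccc1C(N)=O)CC(C)(C)CC2=O` differs from compound 2 in a single place: 1-amino-1-methylethyl in place of aminomethyl on a carbonyl carbon. Among the measured compounds shown here, with no step between measured compounds available, the expectation for this assay rests on the change alone: a small step, downward if anything, of roughly the size of the usual scatter or a little beyond it. Compound 3 is therefore estimated at 30 ug/mL, with a range from 12 ug/mL to 90 ug/mL. The expected step is a 1.5-fold lower number from compound 2 to compound 3 (0.19 log units; within the scatter).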

Compound 3, solubility: > 100 ug/mL
Compound 3: no number, only a limit; the forecaster's own chance of this, stated with the estimate: 10%; middle value at least 3.3-fold (0.52 log units) from the limit.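

Going from aminomethyl to 1-amino-1-methylethyl on a carbonyl carbon, this assay shows an at least 2.1-fold higher number from compound 2 to compound 3 (0.33 log units; beyond the scatter). Within the data shown here, this is the first step at this position that can be read, and it points upward even though the entering group counts 4 heavy atoms against 2 for the one that leaves. The value of compound 3 is a limit and not a number, so the step has only a lower bound, and the read-out gives no view past that limit: the limit of > 100 ug/mL in this assay, at which 2 of the 3 values shown sit.

The compounds shown leave open how far compound 3 lies beyond the limit, and whether the same change would give a step of this kind on the core of compound 1. Also open, going by these compounds, is how a carboxylic acid or a longer chain on this carbonyl carbon would read in this assay.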